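Amine chain variation on a coumarin amide antiproliferative series

This account rests on a few compounds, and the source may have more. Where it says the series, first, only, none or still open, it means among the compounds named here.

Measured compounds:
Compound 1, `CC(=O)Oc1ccc(C(=O)Nc2cc3ccc(OCC4CCCN(C)C4)c(C)c3oc2=O)cc1CC=C(C)C`, gives 740 nM in a functional assay on SK-BR-3 cells (Homo sapiens) for antiproliferative activity; on this read-out lower numbers stand for stronger inhibition and higher numbers for weaker inhibition.
Compound 2, `CCN(CC)CCCOc1ccc2cc(NC(=O)c3ccc(O)c(CC=C(C)C)c3)c(=O)oc2c1C`, gives 4900 nM in this assay.
Compound 3, `CCCNCCCOc1ccc2cc(NC(=O)c3ccc(O)c(CC=C(C)C)c3)c(=O)oc2c1C`, gives 990 nM in this assay.

Compound 3 stands second highest of these three numbers; compound 1 is nearest and differs from it only within the scatter, while compound 2 is furthest. Among the measured compounds shown here, the one step between measured compounds that changes the amine end of the chain, a 4.9-fold lower number from compound 2 to compound 3 (0.69 log units; beyond the scatter), shows that the group on the amine nitrogen can move the number noticeably.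

Compound 4, `CC(C)=CCc1cc(C(=O)Nc2cc3ccc(OCCCNCC(=O)O)c(C)c3oc2=O)ccc1O`, has not yet been measured. It differs from compound 3 as follows: carboxy in place of ethyl on a saturated chain carbon bound to an amine nitrogen. For the measured compounds named here, no measured compound carries a carboxy group, so nothing seen so far bears directly on this exchange; the amine step above only shows that this part of the chain matters. Given compound 3 at 990 nM and the absence of any precedent for a carboxy here, the expectation for compound 4 in this assay is a somewhat higher number, estimated at 3000 nM with a range from 800 nM to 12000 nM, which corresponds to an expected step of a 3.0-fold higher number from compound 3 to compound 4 (0.48 log units; beyond the scatter).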

Compound 4, half-maximal inhibitory concentration: 7570 nM
Estimate against measurement, compound 4: 2.5-fold (0.40 log units) below; measured number inside the range.
By their numbers in this assay, from the lowest: compounds 1 and 3 (each within the scatter of the next); then compounds 2 and 4 (each within the scatter of the next).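

In this assay, carboxy in place of ethyl on a saturated chain carbon bound to an amine nitrogen gives (a 7.6-fold higher number from compound 3 to compound 4 (0.88 log units; beyond the scatter)), so this end of the chain responds to a carboxy group as well as to the alkyl groups compared earlier. The second step (a 1.5-fold higher number from compound 2 to compound 4 (0.19 log units; within the scatter)) stays within the scatter, so the (carboxymethyl)amino and diethylamino chains cannot be told apart here, though each stands clearly apart from the propylamino chain of compound 3. Nothing available explains why the number moves at this position.

The compounds shown leave open how a methyl ester or a primary amide in place of the carboxylic acid would read here. They also leave open whether a longer chain carrying the carboxylic acid would behave the same way.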